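This account rests on a few compounds, and the source may have more. Where it says the series, first, only, none or still open, it means among the compounds named here.

Of the compounds shown here, three of one shared core have been tested in a functional assay on BeWo cells (Homo sapiens) for inhibition, read by MTT assay, with a stated time of 72 h; on this read-out lower numbers stand for stronger inhibition and higher numbers for weaker inhibition. Compound 1 `OCCNc1nnc2nncn2n1` gives 3310 nM, compound 2 `CCCCC(=O)N1CCN(c2nnc3nncn3n2)CC1` gives 1720 nM, and compound 3 `CCCNc1nnc2nncn2n1` gives 14300 nM. Compound 2 thus has the lowest number of the three: the gap to compound 1 is within the usual scatter, while the gap to compound 3 lies beyond it.

The next compound, compound 4 `CN1CCN(c2nnc3nncn3n2)CC1`, differs from compound 2 in one place: methyl in place of butylcarbonyl on an amine nitrogen in a ring.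

Among the compounds with values here, no measured step swaps one group on that ring nitrogen for another, so there is no direct precedent. Within the data shown here, the only measured step, a 4.3-fold higher number from compound 1 to compound 3 (0.64 log units; beyond the scatter), shows that a small change at a chain end can move the number by a modest amount. Since the group that leaves is the larger one and the remaining compounds carry smaller groups with higher numbers, a modest rise is expected for compound 4, a 2.3-fold higher number from compound 2 to compound 4 (0.37 log units; beyond the scatter). Compound 4 is therefore estimated at 4000 nM, with a range from 1200 nM to 14000 nM.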

Compound 4, half-maximal inhibitory concentration: 7990 nM
Beside the measured number, compound 4's estimate is 2.0-fold (0.30 log units) below it; the measured number falls inside the stated range.
By their numbers in this assay, from the lowest: compounds 2 and 1 (each within the scatter of the next); then compounds 4 and 3 (each within the scatter of the next).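

In this assay the change from butylcarbonyl to methyl on the amine nitrogen in the ring gives a 4.6-fold higher number from compound 2 to compound 4 (0.67 log units; beyond the scatter) and so lies beyond the scatter. Within the data shown here, this is the first measured sign that the group on this ring nitrogen affects the number, and here the larger group, butylcarbonyl, goes with the lower number. No measurement on these compounds explains the step.

The swap removes the carbonyl and shortens the chain in one move, so this single step cannot show which of the two matters; a plain butyl group or a small acetyl group on the same nitrogen would separate them. Also open, as far as these compounds go, is whether the number keeps falling with a longer acyl chain, or how a bare amine hydrogen at this nitrogen would compare.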